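A few compounds are considered here, and "the series" means these few. Any claim that something is new, unique, unknown or untested is made for them only; others in the source may bear on it.

Working notes on the series. The shared core is carried by three measured compounds: compound 1 `C[C@@H](O)CCn1nc2c(Br)c(Br)c(Br)c(Br)c2n1`, compound 3 `C[C@H](O)CCn1nc2c(Br)c(Br)c(Br)c(Br)c2n1` and compound 2 `OC(CCn1nc2c(Br)c(Br)c(Br)c(Br)c2n1)c1cccc(Cl)c1`. In a functional assay on CCRF-CEM cells (Homo sapiens) for antiproliferative activity, read by MTT assay, with a stated time of 24 h, tested at 25 uM (on this read-out higher numbers stand for a weaker effect at the one concentration tested and lower numbers for a stronger effect), compound 1 gives 81%, compound 3 gives 112% and compound 2 gives 118%. No measured number stands higher than that of compound 2; compound 3 cannot be told apart from it, while compound 1 lies beyond the scatter below it. For the measured compounds named here, the only step between compounds differing in one place is a number 31 percentage points higher from compound 1 to compound 3 (beyond the scatter), and its cause is no more than the fact that compounds 1 and 3 differ only in the configuration as drawn.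

Compound 4 `OC(CCn1nc2c(Br)c(Br)c(Br)c(Br)c2n1)c1ccc(F)cc1` is not yet measured in this assay. It differs from compound 2 as follows: 4-fluorophenyl in place of 3-chlorophenyl on a saturated chain carbon bound to an oxygen on a saturated carbon and a saturated chain carbon. Going by the values given here, no measured step swaps one aryl group for another, so the stereo step gives no direct bearing. The expected step is a number 6 percentage points lower from compound 2 to compound 4 (within the scatter), that is none beyond the scatter. Compound 4 is estimated at 112%, with a range from 92% to 132%.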

Compound 4, a percentage reported as activity, at one concentration (the size of the read-out at that concentration, not a potency): 104%
The estimate for compound 4 lay 8 percentage points above the measured number; measured number inside the range.
By their numbers in this assay, from the lowest: compound 1; then compounds 4, 3 and 2 (each within the scatter of the next, the first and the last beyond it).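

The carbon that carries the aryl group now has a step of its own: in this assay, 4-fluorophenyl in place of 3-chlorophenyl gives a number 14 percentage points lower from compound 2 to compound 4 (beyond the scatter) for this pair. Until now only a change of configuration had moved the number; this step shows that the aryl group can move it too, even though both groups count the same heavy atoms and the same ring. No available observation bears on why this exchange moves the number.

The exchange alters both the halogen and the group's name-given ring position, so the compounds shown cannot separate the two. Also open, on these data alone, are how an unsubstituted phenyl or an amine would stand at this carbon, and whether configuration matters in compound 2 and compound 4, which are drawn without it.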